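Swapping an oxane for a piperidine on the shared core

The compounds below may be only part of what the source reports. "The series", "measured", "known", "first", "only" and "open" are said of these compounds alone.

In a physicochemical assay for solubility, in phosphate buffer, at pH 7.4 (a higher number here means a more soluble compound, a lower number a less soluble compound), compound 2 `COc1cc(C(=O)N2CCCC2)ccc1-c1ccnc2[nH]c(C3CCOCC3)cc12` gives 15000 nM, the lowest of the two numbers measured, while compound 3 `COc1cc(F)ccc1-c1ccnc2[nH]c(C3CCOCC3)cc12` gives 97000 nM. Compound 1 `CN(C)C(=O)CN1CCC(c2cc3c(-c4ccc(=O)n(C5CCC5)c4)ccnc3[nH]2)CC1` reaches only the limit of this assay, > 1000000 nM. Within the data shown here, the one measured step, a 6.5-fold higher number from compound 2 to compound 3 (0.81 log units; beyond the scatter), concerns a change at a different place from the one now considered, so no measured step bears directly on it. Compound 4 `COc1cc(C(=O)N2CCCC2)ccc1-c1ccnc2[nH]c(C3CCNCC3)cc12` differs from compound 2 by piperidin-4-yl in place of oxan-4-yl on an aromatic carbon. Without a comparable measured step, the expectation rests on the unchanged remainder of compound 2; a modest rise is expected, with wide uncertainty, giving a 10-fold higher number from compound 2 to compound 4 (1.00 log units; beyond the scatter). Compound 4 is therefore estimated at 150000 nM, within a range from 40000 nM to 600000 nM.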

Compound 4, solubility: 590000 nM
Beside the measured number, compound 4's estimate is 3.9-fold (0.59 log units) below it; low and high end bracket the measured number.
By their numbers in this assay, from the lowest: compound 2; then compound 3; then compound 4. At a limit, above all of these: compound 1.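

Exchanging oxan-4-yl for piperidin-4-yl on this aromatic carbon keeps the ring size but brings in a hydrogen-bond donor, and it gives a 39-fold higher number from compound 2 to compound 4 (1.59 log units; beyond the scatter) in this assay. This single change at this position is labelled large, whereas the earlier step at another place, a 6.5-fold higher number from compound 2 to compound 3 (0.81 log units; beyond the scatter), is labelled modest. Compound 4 gives a number rather than a limit, so its step can be read in full: the limit of > 1000000 nM in this assay, at which 1 of the 4 values shown sits.

From the compounds shown here alone, whether the rise depends on the free ring nitrogen stays open. An N-methylpiperidin-4-yl group or an open-chain amine at this place could separate those possibilities.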